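Swapping the morpholine amide for its sulfone analogue

This account rests on a few compounds, and the source may have more. Where it says the series, first, only, none or still open, it means among the compounds named here.

For the measured compounds named here, compound 2 `CC(C)[C@H](NC(=O)[C@H](CC(=O)O)NC(=O)CCCOc1ccc(C(=N)N)cc1)C(=O)N1CCOCC1` is the stronger of the two compounds measured so far in a functional assay with Homo sapiens as the target, in the presence of a further agent that is not named here (a lower number here means a stronger inhibitor, a higher number a weaker inhibitor), where compound 2 gives 79 nM. Going by the values given here, its only measured neighbour is compound 1 `CC(C)[C@H](NC(=O)[C@H](CC(=O)O)NC(=O)CCCOc1ccc(C(=N)N)cc1)C(N)=O`, which in this assay gives 670 nM; the step of an 8.5-fold lower number from compound 1 to compound 2 (0.93 log units; beyond the scatter) shows that replacing the plain amide with a morpholine amide at the carbonyl carbon paid off. Compound 3 `CC(C)[C@H](NC(=O)[C@H](CC(=O)O)NC(=O)CCCOc1ccc(C(=N)N)cc1)C(=O)N1CCS(=O)(=O)CC1` keeps everything else and changes that same position: 1,1-dioxothiomorpholin-4-yl in place of morpholin-4-yl on a carbonyl carbon.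

Among the compounds with values here, only one measured step is available, and it concerns a different change at this carbonyl carbon. It tells that the position accepts a six-membered non-aromatic ring with two hetero atoms, but says nothing about exchanging one such ring for another. With the same ring size and shape retained, and with no comparison of this kind in hand, the outcome is expected to stay close to compound 2. Compound 3 is therefore expected to give about 90 nM in this assay, within 35 nM to 250 nM. The expected step of a 1.1-fold higher number from compound 2 to compound 3 (0.06 log units; within the scatter) is estimated to lie within the scatter.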

Compound 3, half-maximal inhibitory concentration: 30 nM
Compound 3: the middle estimate sits 3.0-fold (0.48 log units) above what was measured; measured number outside the range, below it.
By their numbers in this assay, from the lowest: compound 3; then compound 2; then compound 1.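

In this assay, exchanging one six-membered non-aromatic ring for another at this carbonyl carbon is not a neutral move: a 2.6-fold lower number from compound 2 to compound 3 (0.42 log units; beyond the scatter) is a modest step, but one beyond the scatter. The position therefore tells apart two rings of the same ring size, which the step from the plain amide could not show. Measured from that plain amide, the ring with the sulfone goes further, with a 22-fold lower number from compound 1 to compound 3 (1.35 log units; beyond the scatter) as a large step, and this makes the 1,1-dioxothiomorpholin-4-yl amide the lowest number among the three compounds. No supporting data bear on why the number falls with this ring.

What the compounds leave open is which part of the new group matters: plain thiomorpholin-4-yl, with sulfur in the ring and no oxygen attached to it, would separate the sulfur from the sulfone. Also open, as far as these compounds go, is how this carbonyl carbon would respond to piperazin-1-yl, which carries an amine in the ring, or to an open-chain amide bearing a sulfone, with no ring at all.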